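Trading a five-membered ring for a six-membered one on compound 1

The source may report more compounds than this note shows. Statements on the series, on what has been measured and on what is new or still open speak of the compounds shown alone.

Measured so far:
- compound 1, `CCOC(=O)c1ccc(NC(=O)NCc2cocn2)cc1`: 27600 nM
- compound 2, `CCN(CC)S(=O)(=O)c1ccc(NC(=O)NCc2ccncc2)cc1`: 384 nM

In an assay on isolated protein for activation of Nicotinamide phosphoribosyltransferase (Homo sapiens) (a higher number here means that more compound is needed for the effect, a lower number that less compound is needed), compound 1 gives 27600 nM, the highest of the two numbers seen, meaning it needs the most compound for the effect. Compound 2 gives 384 nM, a far lower number, well beyond the usual scatter; the two differ in more than one place, so no single change can be credited.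

Compound 3, `CCOC(=O)c1ccc(NC(=O)NCc2ccncn2)cc1`, is not yet measured. It differs from compound 1 in one place: pyrimidin-4-yl in place of 1,3-oxazol-4-yl on a saturated chain carbon bound to an amide-type nitrogen. The rest of the shared core is unchanged.

Within the data shown here, no measured pair isolates this change, so the expectation rests on little. A moderate step in this assay from compound 1 to compound 3 is expected, in the direction of a lower number, a 3.1-fold lower number from compound 1 to compound 3 (0.49 log units; beyond the scatter), with wide uncertainty. Compound 3 is therefore estimated at 9000 nM, within the range 2500 nM to 30000 nM.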

Compound 3, half-maximal effective concentration: 13600 nM
Beside the measured number, compound 3's estimate is 1.5-fold (0.18 log units) below it, within the range that was stated.
By their numbers in this assay, from the lowest: compound 2; then compound 3; then compound 1.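

In this assay pyrimidin-4-yl in place of 1,3-oxazol-4-yl on a saturated chain carbon bound to an amide-type nitrogen gives a 2.0-fold lower number from compound 1 to compound 3 (0.31 log units; beyond the scatter) and so shows that this position responds to the ring it carries, if only modestly. Both rings have the same counts of hydrogen-bond donors and acceptors and no net charge, so those counts do not separate them, and what changes is the ring size and the ring atoms. Among these compounds, nothing measured so far explains the step.

Going by these compounds, how a phenyl ring with no hetero atoms, or a plain amine, would fare at this place on the core of compound 1 remains open. Also open, on these data alone, is whether the same ring exchange would give a similar step on a different core.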